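Amide-side variation in a short efficacy series: note on compound 4

A few compounds are considered here, and "the series" means these few. Any claim that something is new, unique, unknown or untested is made for them only; others in the source may bear on it.

Measured so far:
compound 1 `CCCC(=O)Nc1c(C(O)(C(F)(F)F)C(F)(F)F)ccc2ccccc12`: 92%
compound 2 `C/C=C/C(=O)Nc1c(C(O)(C(F)(F)F)C(F)(F)F)ccc2ccccc12`: 96%
compound 3 `O=C(Nc1c(C(O)(C(F)(F)F)C(F)(F)F)ccc2ccccc12)C1CCC1`: 97%

In a functional assay (Sus scrofa) with sulfonylurea receptors; K-ATP channels (Homo sapiens) as the target (on this read-out higher numbers stand for larger maximal responses and lower numbers for smaller maximal responses), compound 3 holds the highest of the three numbers, but the gaps a number 1 percentage points higher from compound 2 to compound 3 (within the scatter) and a number 5 percentage points higher from compound 1 to compound 3 (within the scatter) both lie within the scatter, so the three compounds are not separated.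

Compound 4 `Cc1cccc(C(=O)Nc2c(C(O)(C(F)(F)F)C(F)(F)F)ccc3ccccc23)c1` is not yet measured. Its change from compound 3 is 3-methylphenyl in place of cyclobutyl on a carbonyl carbon. All three measured steps concern the group on the same carbonyl carbon: a number 4 percentage points higher from compound 1 to compound 2 (within the scatter), a number 5 percentage points higher from compound 1 to compound 3 (within the scatter) and a number 1 percentage points higher from compound 2 to compound 3 (within the scatter) were each within the scatter. From this, no step beyond the scatter is expected for compound 4 in this assay, meaning a number 2 percentage points lower from compound 3 to compound 4 (within the scatter). Compound 4 is therefore estimated at 95%, with a range from 83% to 103%.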

Compound 4, largest response reached (reported as efficacy), in percent of the reference or control that the assay uses: 97%
Compound 4: the middle estimate sits 2 percentage points below what was measured; the range from low to high includes it.
By their numbers in this assay, from the lowest: compounds 1, 2, 3 and 4 (each within the scatter of the next).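

In this assay, the carbonyl carbon bearing the amide-type nitrogen accepts an aromatic group, 3-methylphenyl, with all three new steps within the scatter: no change at the digits printed from compound 3 to compound 4 (within the scatter) and a number 1 percentage points higher from compound 2 to compound 4 (within the scatter) and a number 5 percentage points higher from compound 1 to compound 4 (within the scatter). Propyl, prop-1-en-1-yl, cyclobutyl and now a six-membered aromatic ring of 7 heavy atoms are thus not separated at this place. No supporting data bear on this result.

From the compounds shown here alone, whether an amine, a carboxylic acid or a chain longer than propyl on this carbonyl carbon would stay within the scatter remains open. Changes to the shared core also remain open.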